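Amide aryl swaps on the shared core and solubility

The compounds below may be only part of what the source reports. "The series", "measured", "known", "first", "only" and "open" are said of these compounds alone.

Compound 3 `COc1ccc2nc(C)cc(OCC(=O)Nc3ccc(F)cc3)c2c1` stands highest of the three measured in a physicochemical assay for solubility, in phosphate buffer, measured as kinetic solubility, with a stated time of 1 h, at pH 7.4 (on this read-out higher numbers stand for higher solubility and lower numbers for lower solubility), where compound 3 gives 104000 nM. Compound 1 `COc1ccc2nc(C)cc(OCC(=O)Nc3cc(C)ccc3OC)c2c1` gives 9500 nM and compound 2 `COc1ccc2nc(C)cc(OCC(=O)Nc3ccc(Cl)cc3Cl)c2c1` gives 20500 nM in this assay. Within the data shown here, the only changes measured so far sit on the amide-type nitrogen: an 11-fold higher number from compound 1 to compound 3 (1.04 log units; beyond the scatter), a 5.1-fold higher number from compound 2 to compound 3 (0.71 log units; beyond the scatter) and a 2.2-fold higher number from compound 1 to compound 2 (0.33 log units; beyond the scatter), so the group on that nitrogen has moved the read-out by modest to large amounts in every case.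

Compound 4 `COc1ccc2nc(C)cc(OCC(=O)Nc3noc(C)c3C)c2c1` differs from compound 3 as follows: 4,5-dimethyl-1,2-oxazol-3-yl in place of 4-fluorophenyl on an amide-type nitrogen. Among the measured compounds shown here, no measured step exchanges a six-membered aromatic ring of carbon only for a five-membered aromatic ring with hetero atoms, so no direct precedent exists. The measured steps show that compound 3 already sits at the top of the series, and the new group is a small aromatic ring of similar size. A step of a 1.2-fold higher number from compound 3 to compound 4 (0.06 log units; within the scatter) is expected, which could still fall within the scatter. Compound 4 is therefore estimated at 120000 nM, with a range of 35000 nM to 320000 nM.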

Compound 4, solubility: 196000 nM
For compound 4 the middle estimate is 1.6-fold (0.21 log units) below the measured one; low and high end bracket the measured number.
By their numbers in this assay, from the lowest: compound 1; then compound 2; then compounds 3 and 4 (each within the scatter of the next).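

In this assay, a 1.9-fold higher number from compound 3 to compound 4 (0.28 log units; within the scatter) lies within the scatter, so on the amide-type nitrogen 4,5-dimethyl-1,2-oxazol-3-yl and 4-fluorophenyl cannot be told apart. Among these compounds, this is the first sign that the position accepts a five-membered aromatic ring with 2 hetero atoms as well as a six-membered aromatic ring of carbon only, with no loss on this read-out. The same ring stands well clear of the two substituted phenyl groups, with a 9.6-fold higher number from compound 2 to compound 4 (0.98 log units; beyond the scatter) and a 21-fold higher number from compound 1 to compound 4 (1.31 log units; beyond the scatter), both beyond the scatter.

No supporting data bear on the cause of these steps.

Open, from the compounds shown here alone, is whether the two methyl groups on the 1,2-oxazole ring contribute to the number. Also open, going by these compounds, is how an amine or a carboxylic acid on the group at this nitrogen would read.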